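This account rests on a few compounds, and the source may have more. Where it says the series, first, only, none or still open, it means among the compounds named here.

Measured so far in an ADME assay on A549 cells (Homo sapiens) for inhibition, read by MTT assay, with a stated time of 48 h; on this read-out higher numbers stand for weaker inhibition of growth and lower numbers for stronger inhibition of growth:

compound 1, `O=[N+]([O-])c1ccc(Cn2cc(COc3ccccc3)nn2)cc1`: > 100 ug/mL
compound 2, `Cc1ccc(OCc2cn(Cc3ccc([N+](=O)[O-])cc3)nn2)cc1`: > 100 ug/mL

Compound 2 stands only at a limit of this assay, not at a number. The same holds for compound 1, whose value is likewise a limit. Among the measured compounds shown here, the single measured step, a step that the two limits leave unreadable from compound 1 to compound 2, therefore cannot be read for size or direction, and the evidence the limit of > 100 ug/mL in this assay, at which 2 of the 2 values shown sit, shows that every value in the set sits at that limit. For the measured compounds named here, no measured step gives a usable size.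

Compound 3, `O=[N+]([O-])c1ccc(Cn2cc(COc3ccc(Cl)cc3)nn2)cc1`, differs from compound 2 by chloro in place of methyl on an aromatic carbon. Going by the values given here, the only step that bears on this change is the unreadable one from compound 1 to compound 2, so nothing measured points to any step beyond the scatter in this assay in either direction.

Compound 3 is accordingly expected to remain at the limit of this assay, with an estimate of 150 ug/mL and a range from 60 ug/mL to 400 ug/mL. The expected step that the limit leaves unreadable from compound 2 to compound 3 is estimated as none beyond the scatter, and most likely only a limit will be reported.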

Compound 3, concentration for 50% growth inhibition: > 100 ug/mL
Compound 3 ended at the assay's limit (the forecaster's own chance of this, stated with the estimate: 80%); the middle value does not contradict the limit.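

Compound 3 gives > 100 ug/mL in this assay, a limit and not a number. No step among compound 1, compound 2 and compound 3 can be read: the limit of > 100 ug/mL in this assay, at which 3 of the 3 values shown sit.

The compounds shown leave open whether any group at this place, or any change elsewhere on the shared core, gives a readable number in this assay.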